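Swapping isopropyl for phenyl on the amide carbonyl

The source may report more compounds than this note shows. Statements on the series, on what has been measured and on what is new or still open speak of the compounds shown alone.

Measured so far in an assay on CHO-K1 cells for displacement of a labelled ligand from prostaglandin E2 receptor EP1 subtype (Homo sapiens); on this read-out higher numbers stand for weaker inhibition and lower numbers for stronger inhibition:
- compound 1 `CNC(=O)c1cc(C)n(Cc2cc(Cl)ccc2OCc2ccccc2)n1` gives 100 nM
- compound 2 `Cc1cc(C(=O)Nc2ccccc2)nn1Cc1cc(Cl)ccc1OCc1ccccc1` gives 39.8 nM
- compound 3 `Cc1cc(NC(=O)C(C)C)nn1Cc1cc(Cl)ccc1OCc1ccccc1` gives 25.1 nM

Compound 3 has the lowest number of the three, but its gap to compound 2 is within the scatter, so the two cannot be ranked; only compound 1 stands clearly higher, as a 4.0-fold lower number from compound 1 to compound 3 (0.60 log units; beyond the scatter) shows.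

Compound 4 `Cc1cc(NC(=O)c2ccccc2)nn1Cc1cc(Cl)ccc1OCc1ccccc1` is compound 3 with one change: phenyl in place of isopropyl on a carbonyl carbon. Within the data shown here, two measured steps bear on it loosely. Replacing a small alkyl with phenyl, though on the amide-type nitrogen rather than the carbonyl carbon, gave a 2.5-fold lower number from compound 1 to compound 2 (0.40 log units; beyond the scatter). Reversing the amide and changing the carbon group gave a 1.6-fold lower number from compound 2 to compound 3 (0.20 log units; within the scatter), a step within the scatter. Together these suggest that phenyl in place of a small alkyl tends to give a modest lowering, or none beyond the scatter. For compound 4 a modest lowering is therefore expected, a 1.7-fold lower number from compound 3 to compound 4 (0.22 log units; within the scatter), with the estimate 15 nM and a range from 5 nM to 50 nM in this assay.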

Compound 4, half-maximal inhibitory concentration: 15.9 nM
Compound 4: the middle estimate sits 1.1-fold (0.03 log units) below what was measured; the measured number falls inside the stated range.
By their numbers in this assay, from the lowest: compounds 4, 3 and 2 (each within the scatter of the next, the first and the last beyond it); then compound 1.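

In this assay the carbonyl carbon of this amide carries either isopropyl or phenyl with no difference that can be read (a 1.6-fold lower number from compound 3 to compound 4 (0.20 log units; within the scatter)), so a six-membered aromatic ring is tolerated there as well as isopropyl is. With phenyl present in both compounds, benzamido in place of phenylcarbamoyl gives a step beyond the scatter (a 2.5-fold lower number from compound 2 to compound 4 (0.40 log units; beyond the scatter)), the first clear sign that the direction of the amide on the shared core matters. Benzamido in place of methylcarbamoyl gives the widest step seen so far (a 6.3-fold lower number from compound 1 to compound 4 (0.80 log units; beyond the scatter)), although compound 4 and compound 3 cannot be ranked.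

No measurement shown here explains these differences. Still open, on these data alone, is how this assay would respond to a longer alkyl chain, an amine or a carboxylic acid on the carbonyl carbon.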